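A few compounds are considered here, and "the series" means these few. Any claim that something is new, unique, unknown or untested is made for them only; others in the source may bear on it.

Measured in an ADME assay on HEK293 cells (Homo sapiens) for cytotoxicity, with a stated time of 72 h; on this read-out higher numbers stand for an effect only at larger amounts of compound and lower numbers for an effect already at smaller amounts:
- Compound 1 `Cc1cc(NC(=O)Nc2ccc(F)cc2)c2ccccc2n1`: > 25000 nM (a limit of the assay)
- Compound 2 `Cc1cc(NC(=O)Nc2ccc(C(F)(F)F)cc2)c2ccccc2n1`: 25000 nM

Among the measured compounds shown here, compound 2, at 25000 nM, holds the only actual number so far, so there is no range of numbers to place it in. Compound 3 `Cc1cc(NC(=O)Nc2ccc(O)cc2)c2ccccc2n1` carries hydroxy in place of the trifluoromethyl of compound 2: hydroxy in place of trifluoromethyl on an aromatic carbon. For the measured compounds named here, the one measured change on this aromatic carbon, a number no higher from compound 1 to compound 2 (the limit leaves the size open), bears on this step, but its size cannot be read. No step beyond the usual scatter is therefore expected in this assay, and the estimated change is no change at the digits printed from compound 2 to compound 3 (within the scatter). The expected value for compound 3 is 25000 nM, with an estimated range from 12500 nM to 50000 nM.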

Compound 3, half-maximal effective concentration: > 25000 nM
Compound 3: no number, only a limit (the forecaster's own chance of this, stated with the estimate: 55%); the middle value sits exactly at the limit.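

In this assay, hydroxy on this aromatic carbon, para to a large group, gives a number no lower from compound 2 to compound 3 (the limit leaves the size open), so a group with a hydrogen-bond donor can sit here and still give no actual number. Compound 3 gives > 25000 nM, which is a limit of the assay, so the step from compound 1 to compound 3 cannot be read. The read-out therefore separates these groups poorly: the limit of > 25000 nM in this assay, at which 2 of the 3 values shown sit.

Going by these compounds, an amine or a carboxylic acid at this position remains open. So does whether any group here would change the value by more than the usual scatter; compound 2 gives 25000 nM.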